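Solubility of a fluoronaphthyl pyridinone series: an unmeasured analogue

The compounds below may be only part of what the source reports. "The series", "measured", "known", "first", "only" and "open" are said of these compounds alone.

Measured compounds:
- compound 1, `CC(C)C(c1ncc[nH]1)c1ccc(-c2ccc3cccc(F)c3c2)[nH]c1=O`: 20600 nM
- compound 2, `CC(C)C(Nc1nccs1)c1ccc(-c2ccc3cccc(F)c3c2)[nH]c1=O`: 16100 nM
- compound 3, `CC(C)C(CC(N)=O)c1ccc(-c2ccc3cccc(F)c3c2)[nH]c1=O`: 5600 nM

The three compounds share one core and differ only in the group on a saturated chain carbon bound to an aromatic carbon and a saturated chain carbon. In a physicochemical assay for solubility, in phosphate buffer, measured as kinetic solubility (on this read-out higher numbers stand for higher solubility and lower numbers for lower solubility), compound 1 gives the highest of the three numbers. Its nearest neighbour is compound 2: a 1.3-fold lower number from compound 1 to compound 2 (0.11 log units; within the scatter). The step to compound 3 is larger: a 3.7-fold lower number from compound 1 to compound 3 (0.57 log units; beyond the scatter). The step between the other two also points the same way: a 2.9-fold lower number from compound 2 to compound 3 (0.46 log units; beyond the scatter).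

Compound 4, `CC(C)C(Cc1noc(=O)[nH]1)c1ccc(-c2ccc3cccc(F)c3c2)[nH]c1=O`, has not yet been measured. It differs from compound 1 as follows: a group of 7 heavy atoms (3 carbon, 2 nitrogen, 2 oxygen; one five-membered aromatic ring with 3 hetero atoms) in place of a group of 5 heavy atoms (3 carbon, 2 nitrogen; one five-membered aromatic ring with 2 hetero atoms), on a saturated chain carbon bound to an aromatic carbon and a saturated chain carbon. The new group enters through a single chain carbon, much as the carbamoylmethyl group of compound 3 does, so the step from compound 1 to compound 3 bears most on this case, while the step to compound 2 shows that a swap of one aromatic group for another can also leave the number unchanged. Taken together, a modest downward step is expected, a 2.1-fold lower number from compound 1 to compound 4 (0.31 log units; beyond the scatter), in this assay. Compound 4 is therefore estimated at 10000 nM, within a range from 4000 nM to 25000 nM.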

Compound 4, solubility: 30400 nM
Compound 4: the middle estimate sits 3.0-fold (0.48 log units) below what was measured, and the stated range ends below it.
By their numbers in this assay, from the lowest: compound 3; then compounds 2, 1 and 4 (each within the scatter of the next).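

In this assay, the ring of compound 4 enters through a single chain carbon, as the carbamoylmethyl group of compound 3 does, yet the lower number of compound 3 does not carry over: there is a 5.4-fold higher number from compound 3 to compound 4 (0.73 log units; beyond the scatter), whereas there is a 1.5-fold higher number from compound 1 to compound 4 (0.17 log units; within the scatter) and a 1.9-fold higher number from compound 2 to compound 4 (0.28 log units; within the scatter). At this position, on a saturated chain carbon bound to an aromatic carbon and a saturated chain carbon, an entry through a chain carbon therefore does not by itself go with the lower number, and compound 3 alone stands beyond the scatter from each of the other three, while compounds 1, 2 and 4 all lie within the scatter of one another. The material shown holds no evidence that bears on this result.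

From the compounds shown here alone, it remains open whether the ring or the chain carbon through which it enters matters more, and a 1H-imidazol-2-yl group carried on one chain carbon would address that question. Also open, going by these compounds, is how this assay would respond to a carboxylic acid or an amine at this place, or to a longer chain carrying the ring of compound 4.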